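This account rests on a few compounds, and the source may have more. Where it says the series, first, only, none or still open, it means among the compounds named here.

Working notes on the series.

Three compounds share one core and differ only in the group on the five-membered ring of compound 1 `COC(=O)c1cnc(C(=O)CCc2ccc(COc3ccccc3)cc2)o1`. In an assay for inhibition of Fatty-acid amide hydrolase 1 (Rattus norvegicus) (on this read-out higher numbers stand for weaker inhibition and lower numbers for stronger inhibition), compound 1 gives 1.6 nM. Compound 2 `CN(C)C(=O)c1cnc(C(=O)CCc2ccc(COc3ccccc3)cc2)o1` carries dimethylcarbamoyl in that place and in this assay compound 2 gives 6.7 nM. Compound 3 `O=C(CCc1ccc(COc2ccccc2)cc1)c1ncco1` carries hydrogen there, and in this assay compound 3 gives 25 nM, the highest of the three numbers. The two steps that lead to it are a 16-fold higher number from compound 1 to compound 3 (1.19 log units; beyond the scatter) and a 3.7-fold higher number from compound 2 to compound 3 (0.57 log units; beyond the scatter); between the two substituted compounds the step is a 4.2-fold higher number from compound 1 to compound 2 (0.62 log units; beyond the scatter).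

Compound 4 `CNC(=O)c1cnc(C(=O)CCc2ccc(COc3ccccc3)cc2)o1` is the next member, differing from compound 3 by methylcarbamoyl in place of hydrogen on an aromatic carbon. Both measured steps bear on it, read in reverse: putting methoxycarbonyl onto the bare ring lowered the number by a large step, putting dimethylcarbamoyl onto it lowered the number by a modest step. Methylcarbamoyl stands closer to dimethylcarbamoyl than to methoxycarbonyl, so a lowering of at least the size seen with compound 2 is expected, possibly somewhat more.

For compound 4 the expected value in this assay is 4.5 nM, within 1.5 nM to 13 nM. The expected step is therefore a 5.6-fold lower number from compound 3 to compound 4 (0.74 log units; beyond the scatter), a lowering beyond the scatter.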

Compound 4, inhibition constant: 3.6 nM
For compound 4 the middle estimate is 1.3-fold (0.10 log units) above the measured one; low and high end bracket the measured number.
By their numbers in this assay, from the lowest: compound 1; then compounds 4 and 2 (each within the scatter of the next); then compound 3.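

Methylcarbamoyl on the bare ring gives a clear gain in this assay (a 6.9-fold lower number from compound 3 to compound 4 (0.84 log units; beyond the scatter)), so compounds 1, 2 and 4 now all carry a carbonyl-linked group on this aromatic carbon next to the ring oxygen, and each has a lower number than compound 3, with none of the three going against this. The amide nitrogen with one methyl or with two cannot be told apart here (a 1.9-fold lower number from compound 2 to compound 4 (0.27 log units; within the scatter)), which means the presence of the amide hydrogen in compound 4 has no effect that can be read beyond the scatter. Compound 1 still sits ahead of the secondary amide (a 2.3-fold higher number from compound 1 to compound 4 (0.35 log units; beyond the scatter)), so the methoxy-to-methylamino swap on this carbonyl carbon costs a modest step, as did the swap to dimethylamino in compound 2.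

The data shown give no measured basis for explaining any of these steps. Open, on these data alone, is how a carbamoyl group with a bare nitrogen, a carboxylic acid, a nitrile or a longer ester chain would stand at this place relative to compound 1 and compound 4.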